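Methyl for methoxy: working notes toward compound 4

A few compounds are considered here, and "the series" means these few. Any claim that something is new, unique, unknown or untested is made for them only; others in the source may bear on it.

Measured so far in a functional assay on MCF7 cells (Homo sapiens) for cytotoxicity, read by MTT assay, with a stated time of 72 h; on this read-out lower numbers stand for stronger inhibition and higher numbers for weaker inhibition:
compound 1, `COc1cc2ncnc(NNC(=S)NC(=O)c3ccccc3)c2cc1OC`, gives 6990 nM
compound 2, `COc1ccccc1C(=O)NC(=S)NNc1ncnc2ccccc12`, gives 8700 nM
compound 3, `COc1cc2ncnc(NNC(=S)NC(=O)c3ccc(Cl)cc3)c2cc1OC`, gives 8940 nM

Compound 2 holds the second highest of the three numbers, yet compound 3 and compound 1 both lie within the scatter of it, so the three are not told apart.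

Compound 4, `Cc1ccccc1C(=O)NC(=S)NNc1ncnc2ccccc12`, differs from compound 2 by methyl in place of methoxy on an aromatic carbon. Within the data shown here, the only single step measured, a 1.3-fold higher number from compound 1 to compound 3 (0.11 log units; within the scatter), concerns another group at another place and stayed within the scatter; no measured step speaks to methyl replacing methoxy. With nothing pointing either way, no step beyond the scatter is expected in this assay. The expected step is a 1.0-fold higher number from compound 2 to compound 4 (0.01 log units; within the scatter). Compound 4 is therefore estimated at 9000 nM, with a range of 4000 nM to 20000 nM.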

Compound 4, half-maximal inhibitory concentration: 16500 nM
The estimate for compound 4 lay 1.8-fold (0.26 log units) below the measured number; the range from low to high includes it.
By their numbers in this assay, from the lowest: compounds 1, 2, 3 and 4 (each within the scatter of the next, the first and the last beyond it).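

In this assay, methyl in place of methoxy, ortho to a large group, gives a 1.9-fold higher number from compound 2 to compound 4 (0.28 log units; within the scatter). Among these compounds, this is the first reading at this place, and it shows that the oxygen of the methoxy can be lost without a step beyond the scatter. Nothing measured bears on the reason for the size of this step.

Open, as far as these compounds go, is whether an amine or a carboxylic acid at this place would give a step beyond the scatter. Also open, from the compounds shown here alone, is whether a longer chain would do so.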